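Triazole carboxamide series: aminoisoquinoline to pyrrolopyrimidine swap

The source may hold more compounds than are shown below. What is called first, only, known or untested is meant among the compounds shown, and "the series" means these compounds.

Measured compounds:
compound 1 `Cc1ccc(NC(=O)c2ncn(CC(=O)NCCn3ccc4c(N)ncnc43)n2)cc1C` – "not determined" (no result reported)
compound 2 `CC(C)(C)c1ccc(NC(=O)c2ncn(CC(=O)NCc3ccc4[nH]ncc4c3)n2)cc1` – "not determined" (no result reported)
compound 3 `CC(C)(C)c1ccc(NC(=O)c2ncn(CC(=O)NCc3ccc4c(N)nccc4c3)n2)cc1` – 61500 nM

Among the compounds with values here, compound 3 carries the only number in the set; in an assay on isolated protein for inhibition of protein arginine N-methyltransferase 7 (Homo sapiens), read by 33P incorporation (on this read-out higher numbers stand for weaker inhibition and lower numbers for stronger inhibition), compound 3 gives 61500 nM, a weak result. In this assay compound 1 gives "not determined" (no result reported) and compound 2 gives "not determined" (no result reported), so neither contributes a number to compare against. Compound 4 `CC(C)(C)c1ccc(NC(=O)c2ncn(CC(=O)NCCn3ccc4c(N)ncnc43)n2)cc1` differs from compound 3 by a group of 11 heavy atoms (7 carbon, 4 nitrogen; one five-membered aromatic ring with 1 hetero atom, one six-membered aromatic ring with 2 hetero atoms) in place of a group of 11 heavy atoms (9 carbon, 2 nitrogen; one six-membered aromatic ring of carbon only, one six-membered aromatic ring with 1 hetero atom), on a saturated chain carbon bound to an amide-type nitrogen. Within the data shown here, no step between measured compounds is available, so the effect of this exchange is untested in this assay. Compound 4 is expected to come out stronger than compound 3, with the step of a 7.7-fold lower number from compound 3 to compound 4 (0.89 log units; beyond the scatter) estimated as larger than the scatter but held with wide uncertainty. Compound 4 is estimated at 8000 nM, within a range of 800 nM to 60000 nM.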

Compound 4, half-maximal inhibitory concentration: "not active" (no number reported)
Compound 4: no number reported; no gap can be computed for the estimate.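

Within the data shown here, compound 4 carries no number, so no step from compound 3 can be read, and no other data bear on this result. From the compounds shown here alone, whether the exchange of the 1-aminoisoquinolin-6-yl group shifts inhibition remains open.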